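This account rests on a few compounds, and the source may have more. Where it says the series, first, only, none or still open, it means among the compounds named here.

Measured compounds and their clearance values in an ADME assay on the whole organism (Canis lupus familiaris, strain Beagle) for pharmacokinetics; a higher number here means faster removal of the compound, a lower number slower removal:
compound 1 `CCn1c(-c2cnc(C)nc2)nc2c(N[C@H]3CCN(C(=O)C4CCC4)C3)ncnc21`, 11 mL/min/kg;
compound 2 `CCn1c(-c2ccc(C(F)(F)F)nc2)nc2c(O[C@H]3CCN(C(=O)c4cocn4)C3)ncnc21`, 5.6 mL/min/kg;
compound 3 `CCn1c(-c2cnc(C)nc2)nc2c(N[C@H]3CCN(C(=O)[C@H]4C[C@@H](OC)C4)C3)ncnc21`, 7.1 mL/min/kg.

Compound 2 has the lowest of the three numbers, but its gaps to compound 3 and to compound 1 both lie within the scatter, so the three values stand together. Compound 4 `CCn1c(-c2ccc(C(F)(F)F)nc2)nc2c(O[C@H]3CCN(C(=O)C4CCOC4)C3)ncnc21` differs from compound 2 in one place: oxolan-3-yl in place of 1,3-oxazol-4-yl on a carbonyl carbon. Among the compounds with values here, the only measured step, a 1.5-fold lower number from compound 1 to compound 3 (0.19 log units; within the scatter), concerns another group on another core and stays within the scatter, so no measured step bears directly on this change. With nothing pointing either way, compound 4 is expected to show a 1.2-fold higher number from compound 2 to compound 4 (0.06 log units; within the scatter), that is, no step beyond the scatter. The estimate for compound 4 is 6.5 mL/min/kg, with an expected range from 3 mL/min/kg to 14 mL/min/kg.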

Compound 4, clearance: 3.4 mL/min/kg
Compound 4: middle estimate off by 1.9-fold (0.28 log units), on the high side; the measured number falls inside the stated range.
By their numbers in this assay, from the lowest: compounds 4, 2, 3 and 1 (each within the scatter of the next, the first and the last beyond it).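

On the carbonyl carbon, this assay reads oxolan-3-yl in place of 1,3-oxazol-4-yl as a 1.6-fold lower number from compound 2 to compound 4 (0.22 log units; within the scatter), so here a five-membered non-aromatic ring with one hetero atom stands together with a five-membered aromatic ring with two. An aromatic ring on this carbonyl is therefore not required to keep the number in this range. No measurement here offers an explanation for this result.

The compounds shown leave open how a ring carrying an amine, such as piperidin-4-yl, or a longer open chain would read on this carbonyl carbon, and whether the same swap would read alike on the core of compound 1.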